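Adding one more oxygen to the sulfur group

This account rests on a few compounds, and the source may have more. Where it says the series, first, only, none or still open, it means among the compounds named here.

Measured in a functional assay on HCT-116 cells (Homo sapiens) for antiproliferative activity; a higher number here means a weaker inhibitor, a lower number a stronger inhibitor:
Compound 1 `Cc1nc2cc(Cl)c(Cl)cc2n1C1CCCC1`: 3000 nM
Compound 2 `C[S+]([O-])c1nc2cc(Cl)c(Cl)cc2n1C1CCCC1`: 500 nM

Compound 2, at 500 nM, holds the lower number of the two measured compounds, which makes it the stronger inhibitor. Compound 3 `CS(=O)(=O)c1nc2cc(Cl)c(Cl)cc2n1C1CCCC1` alters the same group: a group of 4 heavy atoms (1 carbon, 2 oxygen, 1 sulfur; no ring) in place of a group of 3 heavy atoms (1 carbon, 1 oxygen, 1 sulfur; no ring), on an aromatic carbon. Going by the values given here, only one measured step bears on this, a 6.0-fold lower number from compound 1 to compound 2 (0.78 log units; beyond the scatter), a modest gain when the sulfur group replaced a single carbon. The new change is smaller, so a smaller step in the same direction is expected in this assay, possibly none beyond the scatter. The estimated size is a 1.4-fold lower number from compound 2 to compound 3 (0.15 log units; within the scatter). For compound 3 the expected value is 350 nM, with an estimated range of 100 nM to 1200 nM.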

Compound 3, half-maximal inhibitory concentration: 600 nM
Beside the measured number, compound 3's estimate is 1.7-fold (0.23 log units) below it; the range from low to high includes it.
By their numbers in this assay, from the lowest: compounds 2 and 3 (each within the scatter of the next); then compound 1.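

In this assay, going by these compounds alone, the second oxygen on the sulfur gives a 1.2-fold higher number from compound 2 to compound 3 (0.08 log units; within the scatter), so at this position the change from the first sulfur group to methylsulfonyl has no effect that can be told from scatter. The gain over the methyl group remains, with a 5.0-fold lower number from compound 1 to compound 3 (0.70 log units; beyond the scatter), and it is shared by both sulfur groups. No evidence is available to explain these results. On these data alone, it remains open whether this gain requires sulfur at all. An amine, a carboxylic acid or a longer chain such as ethylsulfonyl on this aromatic carbon could test that.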